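This account rests on a few compounds, and the source may have more. Where it says the series, first, only, none or still open, it means among the compounds named here.

Measured compounds:
compound 1 `Oc1cccc(-c2cc(-c3cccc(Cl)c3)nc(-c3ccco3)c2)c1`, 3570 nM;
compound 2 `Oc1cccc(-c2cc(-c3ccc(Cl)cc3)nc(-c3ccco3)c2)c1`, 10500 nM;
compound 3 `Oc1ccc(-c2cc(-c3cccc(Cl)c3)nc(-c3ccco3)c2)cc1`, 5220 nM.

In a functional assay on T47D cells (Homo sapiens) for cytotoxicity, read by CCK-8 assay and cell counting, with a stated time of 2 days (a higher number here means a weaker inhibitor, a lower number a stronger inhibitor), compound 1 has the lowest of the three numbers. Compound 3 sits within the scatter of it, shown by a 1.5-fold higher number from compound 1 to compound 3 (0.17 log units; within the scatter), whereas compound 2 lies beyond it, shown by a 2.9-fold higher number from compound 1 to compound 2 (0.47 log units; beyond the scatter). Compound 4 `Oc1cccc(-c2cc(-c3ccccc3)nc(-c3cccc(Cl)c3)c2)c1` differs from compound 1 by phenyl in place of furan-2-yl on an aromatic carbon. Within the data shown here, neither measured step touches the group next to the ring nitrogen, so no direct precedent exists; the two steps only show that changes elsewhere on the shared core moved the numbers by small to modest amounts. Compound 4 is therefore expected to stay close to compound 1, with a 1.3-fold higher number from compound 1 to compound 4 (0.10 log units; within the scatter). The estimate for compound 4 is 4500 nM, ranging from 1500 nM to 13000 nM.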

Compound 4, half-maximal inhibitory concentration: 3700 nM
Compound 4: middle estimate off by 1.2-fold (0.09 log units), on the high side, within the range that was stated.
By their numbers in this assay, from the lowest: compounds 1, 4, 3 and 2 (each within the scatter of the next, the first and the last beyond it).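

Among these compounds, at this position, next to the ring nitrogen, phenyl in place of furan-2-yl gives a 1.0-fold higher number from compound 1 to compound 4 (0.02 log units; within the scatter) in this assay, the first reading here of a change at this site. The pair therefore shows that exchanging this five-membered aromatic ring with 1 hetero atom for a six-membered aromatic ring of carbon only, without the hydrogen-bond acceptor counted for furan-2-yl, leaves no readable difference. No supporting measurement bears on why this is so. As far as these compounds go, whether an amine, a carboxylic acid or a longer alkyl chain at this position would also leave the number within the scatter remains open.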